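Methylsulfanyl for Fluoro: Predicting a Cytotoxicity Value

A few compounds are considered here, and "the series" means these few. Any claim that something is new, unique, unknown or untested is made for them only; others in the source may bear on it.

Compound 1 `O=C(Nc1cccc(F)c1)N[C@H]1CC[C@H](Oc2ccc(F)cc2)CC1` is the starting point. In a functional assay on CRL2813 cells (Homo sapiens) for cytotoxicity, read by sulforhodamine B assay, with a stated time of 5 days (on this read-out lower numbers stand for stronger inhibition and higher numbers for weaker inhibition), compound 1 gives 8300 nM, the higher of the two numbers recorded; the nearest is compound 2 `O=C(Nc1cccc(Cl)c1)N[C@H]1CC[C@H](Oc2ccc(F)cc2)CC1`, which gives 5900 nM. Compound 3 `O=C(Nc1ccccc1I)N[C@H]1CC[C@H](Oc2ccc(F)cc2)CC1` reaches only a limit of the assay, > 20000 nM. Compound 4 `CSc1cccc(NC(=O)N[C@H]2CC[C@H](Oc3ccc(F)cc3)CC2)c1` has not yet been measured; it differs from compound 1 in a single place: methylsulfanyl in place of fluoro on an aromatic carbon.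

The measured step that most resembles this change is a 1.4-fold lower number from compound 1 to compound 2 (0.15 log units; within the scatter), in which one halogen replaced another on the aromatic carbon and the number barely moved. The other two steps, an at least 2.4-fold higher number from compound 1 to compound 3 (0.38 log units; beyond the scatter) and an at least 3.3-fold higher number from compound 2 to compound 3 (0.53 log units; beyond the scatter), exchanged the whole 3-fluorophenyl or 3-chlorophenyl for 2-iodophenyl and both ended at the limit (the limit of > 20000 nM in this assay, at which 1 of the 3 values shown sits), so they speak less directly to a change that leaves the group on the same carbon of the ring. The change to compound 4 does keep its group there, and the shift expected is therefore no larger than the scatter, with the direction uncertain. Compound 4 is accordingly estimated to give about 6500 nM, between 2500 nM and 16000 nM, which would amount to an expected step of a 1.3-fold lower number from compound 1 to compound 4 (0.11 log units; within the scatter).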

Compound 4, half-maximal inhibitory concentration: 11100 nM
Compound 4: middle estimate off by 1.7-fold (0.23 log units), on the low side; low and high end bracket the measured number.
By their numbers in this assay, from the lowest: compounds 2, 1 and 4 (each within the scatter of the next). At a limit, above all of these: compound 3.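

In this assay, the change from a halogen to methylsulfanyl, which brings 2 heavy atoms where fluoro has 1 and 1 hydrogen-bond acceptor where fluoro has 0, gives a 1.3-fold higher number from compound 1 to compound 4 (0.13 log units; within the scatter) and a 1.9-fold higher number from compound 2 to compound 4 (0.27 log units; within the scatter). Compound 1, compound 2 and compound 4 therefore stay within the scatter of one another, so this aromatic carbon now accepts a group that is not a halogen with no change that the read-out can resolve. Compound 3 remains a limit and not a number, and the comparison with it yields only an at least 1.8-fold lower number from compound 3 to compound 4 (0.25 log units; that floor lies within the scatter), so compound 4 is not shown to differ from it beyond the scatter: the limit of > 20000 nM in this assay, at which 1 of the 4 values shown sits.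

As far as these compounds go, whether an amine, a carboxylic acid or a longer chain on the same carbon would stay within this narrow band remains open. The compounds shown also do not separate the identity of iodo from its place in 2-iodophenyl, so what lies behind the limit of compound 3 is unresolved.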